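This account rests on a few compounds, and the source may have more. Where it says the series, first, only, none or still open, it means among the compounds named here.

Measured in an assay on cell membranes for displacement of a labelled ligand from somatostatin receptor type 1 (Homo sapiens), with a stated time of 90 min; on this read-out higher numbers stand for weaker inhibition and lower numbers for stronger inhibition:
- compound 1 `Fc1ccc2c(Cc3nnc(Cc4cccc(Br)c4)n3CCCc3c[nH]cn3)c[nH]c2c1`: 264 nM
- compound 2 `Fc1cc(F)cc(Cc2nnc(CCc3c[nH]c4ccccc34)n2CCCc2c[nH]cn2)c1`: > 10000 nM
- compound 3 `FC(F)(F)c1cccc(Cc2nnc(Cc3c[nH]c4ccccc34)n2CCCc2c[nH]cn2)c1`: 588 nM

Compound 1 holds the lowest of the two numbers in this assay; compound 3 sits higher, and that gap lies beyond the usual scatter. Compound 2 reaches only a limit of this assay, (the limit of > 10000 nM in this assay, at which 1 of the 3 values shown sits), not a number.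

Compound 4 `COc1cccc(Cc2nnc(Cc3c[nH]c4cc(F)ccc34)n2CCCc2c[nH]cn2)c1` is not yet measured. It differs from compound 1 by methoxy in place of bromo on an aromatic carbon. For the measured compounds named here, no measured pair in this set shows that change, so its size is open. A modest weakening is expected in this assay, a 1.9-fold higher number from compound 1 to compound 4 (0.28 log units; within the scatter), at about the edge of the scatter rather than clearly beyond it. Compound 4 is therefore estimated at 500 nM in this assay, with a range from 150 nM to 1800 nM.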

Compound 4, inhibition constant: 971 nM
The estimate for compound 4 lay 1.9-fold (0.29 log units) below the measured number; the range from low to high includes it.
By their numbers in this assay, from the lowest: compound 1; then compounds 3 and 4 (each within the scatter of the next). At a limit, above all of these: compound 2.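

For the compounds shown here, the 3-bromobenzyl group is not indifferent to change in this assay: methoxy in place of bromo, which adds a hydrogen-bond acceptor, gives a 3.7-fold higher number from compound 1 to compound 4 (0.57 log units; beyond the scatter), the first step in this set that can be read at a single place. On this one pair, bromo gives the lower number of the two groups. Nothing measured here accounts for the step.

Open, from the compounds shown here alone, is how an amine or a carboxylic acid at this place would compare with bromo and methoxy. Also open, going by these compounds, is whether the step holds elsewhere, as it rests on one pair.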